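The source may report more compounds than this note shows. Statements on the series, on what has been measured and on what is new or still open speak of the compounds shown alone.

Measured so far in an assay on isolated protein for inhibition of protein kinase C zeta type (Homo sapiens), with a stated time of 4 min, tested at 62.5 uM; a lower number here means less inhibition, a higher number more inhibition at the concentration tested (going by the name of the read-out):
compound 1, `CC(C)(C)C1=NN(c2ccc(Br)cc2)C(c2ccc(O)cc2)C1`, gives 93.2%
compound 2, `CC(C)(C)C1=NN(c2ccc(Cl)cc2Cl)C(c2ccc(O)cc2)C1`, gives 71%
compound 3, `CC(C)(C)C1=NN(c2ccc(Cl)cc2)C(c2ccc(Cl)cc2)C1`, gives 11.8%

Compound 3 stands lowest of the three numbers; compound 2 lies nearest to it and compound 1 furthest, both well beyond the scatter. Among the compounds with values here, the only single-point step in the set, a number 22.2 percentage points lower from compound 1 to compound 2 (beyond the scatter), concerns the group on the amine nitrogen in the ring and is modest in size. Compound 4, `CC(C)(C)C1=NN(c2ccc(Cl)cc2)C(c2ccc(C#N)cc2)C1`, is not yet measured. It differs from compound 3 on the other aromatic ring: cyano in place of chloro on an aromatic carbon. Within the data shown here, no measured step touches this ring, so the step 1>2 gives no direct guide. What the values show is that compound 1 and compound 2, which carry a hydroxyphenyl at this place, sit far above compound 3 with its chlorophenyl; cyano brings in one hydrogen-bond acceptor where chloro had none. The step of a number 18.2 percentage points higher from compound 3 to compound 4 (beyond the scatter) is therefore expected to be upward but uncertain in size. For compound 4 in this assay the estimate is 30%, with a range from 5% to 65%.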

Compound 4, a percentage reported as inhibition, at one concentration (the size of the read-out at that concentration, not a potency): 20.7%
Compound 4: middle estimate off by 9.3 percentage points, on the high side; the measured number falls inside the stated range.
By their numbers in this assay, from the lowest: compounds 3 and 4 (each within the scatter of the next); then compound 2; then compound 1.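

In this assay, the step of a number 8.9 percentage points higher from compound 3 to compound 4 (within the scatter) shows that, on this aromatic carbon para to a large group, cyano in place of chloro leaves the two numbers within the scatter of each other. Within the data shown here, this is the first measured change at this position, and the hydrogen-bond acceptor that enters with cyano comes with no difference beyond the scatter. Nothing measured on these compounds offers an explanation for this result.

On these data alone, whether an amine or a carboxylic acid on this aromatic carbon would give a number beyond the scatter of compound 3 remains open. Also open, as far as these compounds go, is how much of the higher numbers of compound 1 and compound 2 belongs to the hydroxyphenyl and how much to the group on the amine nitrogen in the ring.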